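Threonine amide series: carbonyl to sulfonyl change at nitrogen

The source may report more compounds than this note shows. Statements on the series, on what has been measured and on what is new or still open speak of the compounds shown alone.

Measured compounds:
compound 1 `CCCCCCCCCCCCCCCCCCNC(=O)[C@@H](N)[C@@H](C)O` — 39500 nM
compound 2 `CCCCCCCCNC(=O)[C@@H](NC(=O)c1nccc2ccccc12)[C@@H](C)O` — 66000 nM
compound 3 `CCCCCCCCCCCCCCCCCCNC(=O)[C@@H](NC(=O)c1nccc2ccccc12)[C@@H](C)O` — 51200 nM

In a functional assay on SiHa cells (Homo sapiens) for cytotoxicity, read by MTT assay, with a stated time of 48 h (on this read-out higher numbers stand for weaker inhibition and lower numbers for stronger inhibition), compound 3 gives 51200 nM, the second highest of the three numbers; both other compounds sit within the scatter of it, as a 1.3-fold higher number from compound 1 to compound 3 (0.11 log units; within the scatter) and a 1.3-fold lower number from compound 2 to compound 3 (0.11 log units; within the scatter) show. Compound 4 `CCCCCCCCCCCCCCCCCCNC(=O)[C@@H](NS(=O)(=O)c1cccs1)[C@@H](C)O` differs from compound 3 by (thiophen-2-yl)sulfonyl in place of (isoquinolin-1-yl)carbonyl on an amine nitrogen. For the measured compounds named here, the only measured step at the same nitrogen is a 1.3-fold higher number from compound 1 to compound 3 (0.11 log units; within the scatter), where putting the (isoquinolin-1-yl)carbonyl onto the bare amine left the number within the scatter; no measured step swaps a carbonyl for a sulfonyl. A step within the scatter, with no direction, is therefore expected in this assay. For compound 4 the expected value is 50000 nM, range 20000 nM to 130000 nM. The step this estimate implies, a 1.0-fold lower number from compound 3 to compound 4 (0.01 log units; within the scatter), is an expectation only.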

Compound 4, half-maximal inhibitory concentration: > 200000 nM
Compound 4 was reported as a limit; the forecaster's own chance of this, stated with the estimate: 15%; middle value at least 4.0-fold (0.60 log units) away from the limit.
By their numbers in this assay, from the lowest: compounds 1, 3 and 2 (each within the scatter of the next). At a limit, above all of these: compound 4.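

In this assay compound 4 is reported only as a limit of the assay, not as a number: the limit of > 200000 nM in this assay, at which 1 of the 4 values shown sits.

The substituent on this amine nitrogen can matter after all. The bare amine and the (isoquinolin-1-yl)carbonyl stayed within the scatter of each other, whereas (thiophen-2-yl)sulfonyl gives an at least 3.9-fold higher number from compound 3 to compound 4 (0.59 log units; beyond the scatter) and an at least 5.0-fold higher number from compound 1 to compound 4 (0.70 log units; beyond the scatter).

The sulfonyl and the thiophen-2-yl ring enter in one step, and the compounds shown do not separate them. A (thiophen-2-yl)carbonyl or an (isoquinolin-1-yl)sulfonyl on this nitrogen would tell which part carries the weaker inhibition.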